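Mirror-image partners in a cell-layer permeability test

This account rests on a few compounds, and the source may have more. Where it says the series, first, only, none or still open, it means among the compounds named here.

In an ADME assay on Caco-2 cells (Homo sapiens) for permeability, in the apical to basolateral direction (a higher number here means that the compound crosses the layer faster, a lower number that the compound crosses the layer more slowly), compound 1 (`CS(=O)(=O)Nc1ccc2c(c1)S(=O)(=O)N=C(C1=C(O)[C@H]3CCC[C@H]3N(Cc3ccc(F)c(F)c3)C1=O)N2`) gives 0.83 10^-6 cm/s and compound 2 (`CS(=O)(=O)Nc1ccc2c(c1)S(=O)(=O)N=C(C1=C(O)[C@H]3CCCC[C@H]3N(Cc3ccc(F)cc3)C1=O)N2`) gives 0.67 10^-6 cm/s as its reading. Going by the values given here, these two values lie within the usual scatter of each other, so the numbers do not separate compound 2 from the only other compound measured so far.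

The account now turns to compound 3 (`CS(=O)(=O)Nc1ccc2c(c1)S(=O)(=O)N=C(C1=C(O)[C@@H]3CCCC[C@@H]3N(Cc3ccc(F)cc3)C1=O)N2`), which differs from compound 2 only in configuration (the two compounds have the same atoms and bonds and differ only in configuration as drawn: 2 of 2 stereo elements differ (all stereocentres are inverted: mirror images); a stereocentre at a saturated ring carbon is drawn S in compound 2 and R in compound 3; a stereocentre at a saturated ring carbon is drawn R in compound 2 and S in compound 3). The two compounds have the same atoms and bonds, and all stereocentres are inverted, which makes them mirror images. Among the compounds with values here, no mirror-image pair has yet been measured, so the data offer no direct precedent for such a change. With the atoms and bonds unchanged, no shift beyond the scatter is expected in this assay and no direction is favoured. The expectation therefore rests on compound 2 at 0.67 10^-6 cm/s as its anchor. The estimated change, a 1.0-fold higher number from compound 2 to compound 3 (0.02 log units; within the scatter), is expected to stay within the scatter. Compound 3 is expected to give 0.7 10^-6 cm/s (estimated range 0.35 10^-6 cm/s to 1.4 10^-6 cm/s).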

Compound 3, apparent permeability: 1 10^-6 cm/s
Estimate against measurement, compound 3: 1.4-fold (0.15 log units) below; measured number inside the range.
By their numbers in this assay, from the lowest: compounds 2, 1 and 3 (each within the scatter of the next).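

In this assay, the series now holds its first mirror-image pair, and inverting both saturated ring stereocentres gives a 1.5-fold higher number from compound 2 to compound 3 (0.17 log units; within the scatter). Going by these compounds alone, at these two ring carbons, then, the configuration as drawn does not separate the pair in this assay, something compounds 1 and 2 could not show, as no single-place step joins them. The comparison is a clean test of this one change, since no other structural difference enters into it: the fact that compounds 2 and 3 differ only in the configuration as drawn

Whether the mirror image of compound 1 would also stay within the scatter of compound 1 remains an open question, so this one pair cannot yet be read as a rule for the series. As far as these compounds go, it is also open whether the two mirror-image forms would stay this close if an amine or a carboxylic acid were carried on the shared core in place of the methanesulfonamide group.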